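The source may report more compounds than this note shows. Statements on the series, on what has been measured and on what is new or still open speak of the compounds shown alone.

In a functional assay on Ehrlich cells (Mus musculus) for inhibition (a higher number here means a weaker inhibitor, a lower number a stronger inhibitor), compound 3 `O=C(O)c1cnc2cc(F)ccc2c1O` gives 501000 nM and compound 1 `CN(C)c1ccc2c(O)c(C(=O)O)cnc2c1` gives 468000 nM, two values within the scatter of each other, while compound 2 `NS(=O)(=O)c1ccc2c(O)c(C(=O)O)cnc2c1` gives 3390000 nM. Compound 4 `NC(=O)c1ccc2c(O)c(C(=O)O)cnc2c1` has carbamoyl in place of fluoro on an aromatic carbon. Within the data shown here, no measured step makes this exact swap. Among the measured compounds shown here, two measured steps bear on it: the change from sulfamoyl to fluoro was modest, a 6.8-fold lower number from compound 2 to compound 3 (0.83 log units; beyond the scatter), and the change from dimethylamino to fluoro stayed within the scatter, a 1.1-fold higher number from compound 1 to compound 3 (0.03 log units; within the scatter). Of these groups, sulfamoyl seems the closer match to carbamoyl, so a small rise is expected in this assay, pointing to a weaker inhibitor. The expected step is a 2.4-fold higher number from compound 3 to compound 4 (0.38 log units; beyond the scatter). For compound 4 the estimate is 1200000 nM, with an expected range of 400000 nM to 3500000 nM.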

Compound 4, half-maximal inhibitory concentration: 5750000 nM
For compound 4 the middle estimate is 4.8-fold (0.68 log units) below the measured one; measured number above the stated range.
By their numbers in this assay, from the lowest: compounds 1 and 3 (each within the scatter of the next); then compounds 2 and 4 (each within the scatter of the next).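

In this assay the carbamoyl group turns out to weaken inhibition clearly, with an 11-fold higher number from compound 3 to compound 4 (1.06 log units; beyond the scatter) and a 12-fold higher number from compound 1 to compound 4 (1.09 log units; beyond the scatter) as two large steps. Replacing sulfamoyl with carbamoyl leaves the number within the scatter, with a 1.7-fold higher number from compound 2 to compound 4 (0.23 log units; within the scatter) as the step, so the four compounds fall into two groups: compound 1 with compound 3, and compound 2 with compound 4. As far as these compounds go, whether an amine or a nitrile on this aromatic carbon would join the first group or the second stays open. Nothing available here explains this split.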